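A few compounds are considered here, and "the series" means these few. Any claim that something is new, unique, unknown or untested is made for them only; others in the source may bear on it.

Measured so far in an ADME assay on microsomes from liver (Mus musculus) for metabolic stability, read by LC-MS, with a stated time of 30 min, tested at 1 uM; a higher number here means that more of the compound is left, a lower number that less of the compound is left:
- compound 1 `O=C(NCc1ccc(S(=O)(=O)c2ccccc2)cc1)c1cc2ccncc2s1`: 21%
- compound 2 `O=C(NCc1ccc(S(=O)(=O)c2ccccc2)cc1)c1c[nH]c2ccncc12`: 45%

Of these two values, that of compound 1 is the lower. Compound 3 `O=C(NCc1ccc(S(=O)(=O)c2cccc(C(F)(F)F)c2)cc1)c1cc2ccncc2s1` differs from compound 1 by trifluoromethyl in place of hydrogen on an aromatic carbon, with trifluoromethyl in place of hydrogen on an aromatic carbon, meta to a large group. Among the measured compounds shown here, the only measured step, a number 24 percentage points higher from compound 1 to compound 2 (beyond the scatter), lies on a carbonyl carbon, at another place, so it gives no direct guide to size or direction here. No step beyond the scatter is therefore expected in this assay, though the data leave this open. The expected step is a number 1 percentage points lower from compound 1 to compound 3 (within the scatter). For compound 3 the estimated value is 20%, with an expected range from 6% to 40%.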

Compound 3, percent of the compound remaining: 35%
The estimate for compound 3 lay 15 percentage points below the measured number; low and high end bracket the measured number.
By their numbers in this assay, from the lowest: compound 1; then compounds 3 and 2 (each within the scatter of the next).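

The change from phenyl to 3-(trifluoromethyl)phenyl gives, in this assay, a number 14 percentage points higher from compound 1 to compound 3 (beyond the scatter), so this end of the molecule, which the earlier pair left unchanged, also bears on the read-out. A single added group on an aromatic carbon here is enough for a step beyond the scatter. Nothing available explains why this substitution leaves more compound.

As far as these compounds go, whether a nitrile, a methoxy group or an amine at this place would do the same remains open. So does whether trifluoromethyl would give a similar step on the core of compound 2.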